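Cytotoxicity notes on two aryl hydrazone thioacetamides

The source may report more compounds than this note shows. Statements on the series, on what has been measured and on what is new or still open speak of the compounds shown alone.

Measured so far:
compound 1 `COc1ccc(/C=N/NC(=O)CSc2nnc(-c3ccncc3)o2)cc1` – 132000 nM
compound 2 `O=C(CSc1nnc(-c2ccncc2)o1)N/N=C/c1cccc(C(F)(F)F)c1` – 169000 nM

In an ADME assay on NIH3T3 cells (Mus musculus) for cytotoxicity, read by MTT assay, with a stated time of 24 h (a lower number here means a stronger inhibitor, a higher number a weaker inhibitor), compound 1 gives 132000 nM and compound 2 gives 169000 nM; the two numbers lie within the scatter of each other, so neither can be called the stronger. Compound 3 `O=C(CSc1nnc(-c2ccncc2)o1)N/N=C/c1cc(Br)ccc1O` is not yet measured in this assay. It differs from compound 1 in one place: 5-bromo-2-hydroxyphenyl in place of 4-methoxyphenyl on a carbon with a double bond to nitrogen. With no measured step of this kind in the series, nothing here points to a change beyond the scatter, and the step of a 1.2-fold lower number from compound 1 to compound 3 (0.08 log units; within the scatter) is expected to be small. Compound 3 is therefore estimated at 110000 nM, with a range from 40000 nM to 300000 nM.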

Compound 3, half-maximal inhibitory concentration: 156000 nM
Estimate against measurement, compound 3: 1.4-fold (0.15 log units) below; the measured number falls inside the stated range.
By their numbers in this assay, from the lowest: compounds 1, 3 and 2 (each within the scatter of the next).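

Within the data shown here, replacing 4-methoxyphenyl with 5-bromo-2-hydroxyphenyl on a carbon with a double bond to nitrogen gives the first measured step at this place in this assay: a 1.2-fold higher number from compound 1 to compound 3 (0.07 log units; within the scatter). The entering group brings bromine and a hydrogen-bond donor that the leaving group lacks, yet this exchange produces no readable change in the number. No available measurement offers an explanation for the size of this step. Open, from the compounds shown here alone, is whether a carboxylic acid or an amine on this phenyl ring would move the number beyond the scatter. A single step also cannot show how bromine and hydroxy each contribute.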